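A few compounds are considered here, and "the series" means these few. Any claim that something is new, unique, unknown or untested is made for them only; others in the source may bear on it.

Measured so far in an assay on isolated protein for binding affinity to secreted frizzled-related protein 1 (Homo sapiens), read by fluorescence; on this read-out higher numbers stand for weaker inhibition and lower numbers for stronger inhibition:
compound 1, `O=C(CN1CCCC1)N1CCC(NS(=O)(=O)c2cc(S(=O)(=O)c3ccccc3)ccc2C(F)(F)F)CC1`: 110 nM
compound 2, `CCNC(=O)N1CCC[C@H]1C(=O)N1CCC(NS(=O)(=O)c2cc(S(=O)(=O)c3ccccc3)ccc2C(F)(F)F)CC1`: 30 nM

Compound 1 has the higher of the two numbers; its nearest neighbour is compound 2, reached by a 3.7-fold lower number from compound 1 to compound 2 (0.56 log units; beyond the scatter), a step beyond the scatter and modest in size.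

Compound 3, `CN1CCC[C@H]1C(=O)N1CCC(NS(=O)(=O)c2cc(S(=O)(=O)c3ccccc3)ccc2C(F)(F)F)CC1`, is not yet measured. Relative to compound 1 the change is 1-methylpyrrolidin-2-yl in place of (pyrrolidin-1-yl)methyl on a carbonyl carbon. The two compounds hold the same atoms, joined differently: the ring is shifted onto the carbonyl carbon and its nitrogen carries a methyl, with one defined stereocentre.

Among the compounds with values here, only one measured step bears on this change. In the step from compound 1 to compound 2 the same (pyrrolidin-1-yl)methyl left the carbonyl carbon and a 1-(ethylcarbamoyl)pyrrolidin-2-yl entered; the number fell modestly, beyond the scatter. Compound 3 shares the ring placement of compound 2 but has a methyl where compound 2 carries an ethylcarbamoyl, so the step is expected to be smaller than that one, a drop that may or may not clear the scatter.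

For compound 3 the estimate is 60 nM, range 25 nM to 150 nM, which corresponds to an expected step of a 1.8-fold lower number from compound 1 to compound 3 (0.26 log units; within the scatter).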

Compound 3, half-maximal inhibitory concentration: 120 nM
Estimate against measurement, compound 3: 2.0-fold (0.30 log units) below, and the stated range covers the measured number.
By their numbers in this assay, from the lowest: compound 2; then compounds 1 and 3 (each within the scatter of the next).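

In this assay, placing the ring directly on the carbonyl carbon as 1-methylpyrrolidin-2-yl in place of (pyrrolidin-1-yl)methyl leaves the number unresolved from that of the starting compound (a 1.1-fold higher number from compound 1 to compound 3 (0.04 log units; within the scatter)), so this rearrangement of the same atoms shows no measurable effect on its own. On the amine nitrogen in the ring, methyl in place of ethylcarbamoyl gives a modest step beyond the scatter (a 4.0-fold higher number from compound 2 to compound 3 (0.60 log units; beyond the scatter)), so within these three compounds the lower number of compound 2 goes with the ethylcarbamoyl and not with the ring placement alone. No measurement available here explains either step.

Still open, as far as these compounds go, is which part of the ethylcarbamoyl carries the difference, a question that an acetyl, a methylcarbamoyl, a propylcarbamoyl or a plain hydrogen on that ring nitrogen would address. Also open, from the compounds shown here alone, is how the opposite configuration at the defined stereocentre would read, with either methyl or ethylcarbamoyl on the ring nitrogen.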